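Moving the methoxycarbonyl group on the amide nitrogen aryl

The source may hold more compounds than are shown below. What is called first, only, known or untested is meant among the compounds shown, and "the series" means these compounds.

Measured compounds:
compound 2 `CCCCCCCCCCOc1cccc(OCCCCCC(=O)N(Cc2ccc(C(=O)OC)cc2)c2cccc(C(=O)OC)c2)c1` — 86%
compound 1 `CCCCCCCCCCOc1cc(OCCCCCCCCCC)cc(OCCCCCCN(Cc2ccc(C(=O)O)cc2)c2ccc(C(=O)O)cc2)c1` — "not determined" (no result reported)

Two compounds are shown here. In an assay on isolated protein for binding affinity to L-selectin (Homo sapiens), read by ELISA, tested at 500 uM (a higher number here means more inhibition at the concentration tested (going by the name of the read-out), a lower number less inhibition), compound 1 `CCCCCCCCCCOc1cc(OCCCCCCCCCC)cc(OCCCCCCN(Cc2ccc(C(=O)O)cc2)c2ccc(C(=O)O)cc2)c1` gives "not determined" (no result reported), so nothing can be said of it beyond its structure. Going by the values given here, compound 2 `CCCCCCCCCCOc1cccc(OCCCCCC(=O)N(Cc2ccc(C(=O)OC)cc2)c2cccc(C(=O)OC)c2)c1` is the only compound with a number: in this assay compound 2 gives 86%, and with no second measured compound there is no step to set it against, so it simply stands alone as the one reference point.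

Compound 3 `CCCCCCCCCCOc1cccc(OCCCCCC(=O)N(Cc2ccc(C(=O)OC)cc2)c2ccc(C(=O)OC)cc2)c1` is the next compound to be measured. Its difference from compound 2 is 4-(methoxycarbonyl)phenyl in place of 3-(methoxycarbonyl)phenyl on an amide-type nitrogen. Among the compounds with values here, the two have the same atoms joined differently, and no measured pair shows how such a rearrangement plays out in this assay. Without such a precedent, the expected step from compound 2 to compound 3 in this assay is estimated to be small, a number 6 percentage points lower from compound 2 to compound 3 (within the scatter), not clearly beyond the usual scatter in either direction. Compound 3 is therefore expected to give about 80% in this assay, with a range from 60% to 95%.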

Compound 3, a percentage reported as inhibition, at one concentration (the size of the read-out at that concentration, not a potency): 75%
Estimate against measurement, compound 3: 5 percentage points above; the measured number falls inside the stated range.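

Moving the ester, with 4-(methoxycarbonyl)phenyl in place of 3-(methoxycarbonyl)phenyl on the amide-type nitrogen, gives in this assay a number 11 percentage points lower from compound 2 to compound 3 (beyond the scatter), the first step this series offers. The two compounds have the same atoms and the same counts of hydrogen-bond donors and acceptors, so this read-out is sensitive to how the group is attached on this aryl ring and not only to which atoms are present, although the change is modest and compound 3 still shows clear inhibition at the single concentration tested. Nothing else measured here bears on why the step has this direction or size.

This is a single pair, so it cannot show whether the same shift would matter with a different group on the ring or with other changes to the shared core. Going by these compounds, whether a nitrile or a primary amide in place of the methoxycarbonyl group would hold the inhibition, and whether either would show the same dependence on where it is attached, remains open.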